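The source may report more compounds than this note shows. Statements on the series, on what has been measured and on what is new or still open speak of the compounds shown alone.

Three compounds share one core and differ only in the group on a saturated chain carbon bound to a sulfur. Compound 1 `CC(=O)OCC[S+]([O-])CC1CN(C)CCC1c1ccc(Cl)cc1` carries an acetoxymethyl group and in an assay on isolated protein for inhibition of sodium-dependent dopamine transporter (Rattus norvegicus), read by radioligand binding (on this read-out lower numbers stand for stronger inhibition and higher numbers for weaker inhibition), compound 1 gives 9 nM. Compound 2 `CN1CCC(c2ccc(Cl)cc2)C(C[S+]([O-])CC(=O)NO)C1` carries a hydroxycarbamoyl group, and in this assay compound 2 gives 55 nM. Compound 3 `CNC(=O)C[S+]([O-])CC1CN(C)CCC1c1ccc(Cl)cc1` carries a methylcarbamoyl group, and in this assay compound 3 gives 164 nM, the highest of the three numbers: an 18-fold higher number from compound 1 to compound 3 (1.26 log units; beyond the scatter), and a 3.0-fold higher number from compound 2 to compound 3 (0.47 log units; beyond the scatter).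

Compound 4 `Cc1noc(C[S+]([O-])CC2CN(C)CCC2c2ccc(Cl)cc2)n1` changes the same position again: 3-methyl-1,2,4-oxadiazol-5-yl in place of methylcarbamoyl on a saturated chain carbon bound to a sulfur. All three measured steps bear on it, since each alters this very group: a 6.1-fold higher number from compound 1 to compound 2 (0.79 log units; beyond the scatter), an 18-fold higher number from compound 1 to compound 3 (1.26 log units; beyond the scatter) and a 3.0-fold higher number from compound 2 to compound 3 (0.47 log units; beyond the scatter). Every change made so far at this place has shifted the number beyond the scatter, so a step beyond the scatter is expected here too. Compound 3 is expected to be the weakest starting point, and compound 4 is estimated at 60 nM, within 15 nM to 250 nM. The expected step is a 2.7-fold lower number from compound 3 to compound 4 (0.44 log units; beyond the scatter).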

Compound 4, inhibition constant: 1650 nM
Estimate against measurement, compound 4: 28-fold (1.44 log units) below; measured number outside the range, above it.
By their numbers in this assay, from the lowest: compound 1; then compound 2; then compound 3; then compound 4.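

In this assay the 3-methyl-1,2,4-oxadiazol-5-yl group is the only one of the four to place a five-membered aromatic ring at this position, and it gives the highest number of the series (a 10-fold higher number from compound 3 to compound 4 (1.00 log units; beyond the scatter); a 30-fold higher number from compound 2 to compound 4 (1.48 log units; beyond the scatter); a 180-fold higher number from compound 1 to compound 4 (2.26 log units; beyond the scatter)). The earlier compounds shown here, all with open-chain groups here, showed a narrower spread, so this position can shift the number much further than they suggested. Nothing shown here explains the rise.

The compounds shown leave open whether any ring at this position gives such a high number or only this one, which a phenyl or a 1,3,4-oxadiazole would help to test. A carboxylic acid or a primary amide on the same saturated chain carbon bound to a sulfur would extend the open-chain comparison.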